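The source may hold more compounds than are shown below. What is called first, only, known or untested is meant among the compounds shown, and "the series" means these compounds.

Measured so far:
compound 1 `COc1ccc(CN(C(=O)CCCl)c2cc(OC)c(OC)c(OC)c2)cc1O`: 140 nM
compound 2 `COc1ccc(N(Cc2cc(OC)c(OC)c(OC)c2)C(=O)CCl)cc1O`: 24500 nM

In a functional assay on MGC-803 cells (Homo sapiens) for inhibition, read by MTT assay, with a stated time of 48 h (on this read-out lower numbers stand for stronger inhibition and higher numbers for weaker inhibition), compound 1 gives 140 nM, the lowest of the two numbers. Compound 2 gives 24500 nM, a higher number whose gap from compound 1 lies beyond the scatter. Going by the values given here, the two measured compounds differ in more than one place, so no single-change step is available, and nothing measured guides the change considered here.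

Compound 3 `C=CC(=O)N(Cc1ccc(OC)c(O)c1)c1cc(OC)c(OC)c(OC)c1` is the next to be measured in this assay. It differs from compound 1 by vinyl in place of 2-chloroethyl on a carbonyl carbon. Among the compounds with values here, with no measured step of this kind, only a small step is expected, in either direction, or none beyond the scatter. Compound 3 is expected to give about 150 nM in this assay, within a range from 45 nM to 500 nM. The expected step of a 1.1-fold higher number from compound 1 to compound 3 (0.03 log units; within the scatter) rests on compound 1 giving 140 nM and on nothing else.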

Compound 3, half-maximal inhibitory concentration: 62 nM
Compound 3: middle estimate off by 2.4-fold (0.38 log units), on the high side, and the stated range covers the measured number.
By their numbers in this assay, from the lowest: compound 3; then compound 1; then compound 2.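

In this assay the series now has its first single-change step: vinyl in place of 2-chloroethyl on a carbonyl carbon gives a 2.3-fold lower number from compound 1 to compound 3 (0.35 log units; beyond the scatter) as a modest change. This place, on a carbonyl carbon whose other neighbour is an amide-type nitrogen, therefore accepts the swap, and chlorine in the group there is not required for a value in this range. No measurement bearing on the reason for the step is at hand.

An ethyl group at this place would separate the loss of chlorine from the gain of the double bond, and the compounds shown leave that split open. Also open, on these data alone, is how a longer chain, such as 3-chloropropyl or butenyl, or an amine on the chain would read here.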